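The source may hold more compounds than are shown below. What is called first, only, known or untested is meant among the compounds shown, and "the series" means these compounds.

Measured so far: compound 1 `CCNC(=O)c1cccc(Cn2nc(C)c(NC(=O)c3ccc(COc4ccccc4)cc3)c2C)c1` gives 11000 nM; compound 2 `Cc1nn(Cc2cccc(C(=O)Nc3ccccc3)c2)c(C)c1NC(=O)c1ccc(COc2ccccc2)cc1` gives 6400 nM; compound 3 `CNC(=O)c1cccc(Cn2nc(C)c(NC(=O)c3ccc(COC4CCCCC4)cc3)c2C)c1` gives 14000 nM, all in a functional assay on MIA PaCa-2 cells (Homo sapiens) for antiproliferative activity, read by MTT assay, with a stated time of 72 h; a higher number here means that more compound is needed for the effect, a lower number that less compound is needed.

Compound 3 has the highest of the three numbers. Its nearest neighbour is compound 1, whose number sits within the scatter of compound 3; the furthest is compound 2, whose number lies beyond the scatter, so compound 2 needs less compound than compound 3.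

Compound 4 `CNC(=O)c1cccc(Cn2nc(C)c(NC(=O)c3ccc(COc4cccc(OC)c4)cc3)c2C)c1` has not yet been measured. It differs from compound 3 in one place: 3-methoxyphenyl in place of cyclohexyl on an oxygen on a saturated carbon.

Within the data shown here, the only measured step, a 1.7-fold lower number from compound 1 to compound 2 (0.24 log units; within the scatter), concerns a different place, the substituent on an amide-type nitrogen, and says nothing about the ether end of the molecule. Compounds 1 and 3 differ at two places at once, so their two values alone cannot be split into a contribution from the ether end. Among the measured compounds shown here, no measured step therefore bears directly on the change from compound 3 to compound 4. Given that the three numbers all fall in a narrow band, a step of modest size toward a lower number is expected, a 1.6-fold lower number from compound 3 to compound 4 (0.19 log units; within the scatter), but with wide uncertainty.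

Compound 4 is estimated at 9000 nM, within a range of 3000 nM to 25000 nM.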

Compound 4, half-maximal effective concentration: 6200 nM
Compound 4: the middle estimate sits 1.5-fold (0.16 log units) above what was measured, within the range that was stated.
By their numbers in this assay, from the lowest: compounds 4, 2, 1 and 3 (each within the scatter of the next, the first and the last beyond it).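

In this assay, the step at the ether end of the molecule reads a 2.3-fold lower number from compound 3 to compound 4 (0.35 log units; beyond the scatter), with 3-methoxyphenyl in place of cyclohexyl on an oxygen on a saturated carbon and everything else held fixed. This gives the series its first step beyond the scatter from a change in one place, and it shows that this position affects the read-out, which the earlier step on an amide-type nitrogen could not show. The change replaces a non-aromatic carbon ring with an aromatic one and brings in a methoxy group at the same time, so this single step reports their combined result and cannot be divided between them; no measured property is available to account for it.

The compounds shown leave open how much of the step belongs to the aromatic ring and how much to the methoxy group. Also open, on these data alone, is how the read-out would respond to a hydroxyl or dimethylamino group in place of the methoxy group, or to a piperidine ring in place of the aromatic ring on this oxygen.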